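This account rests on a few compounds, and the source may have more. Where it says the series, first, only, none or still open, it means among the compounds named here.

Measured in a functional assay on K562 cells (Homo sapiens) for cytotoxicity, read by CCK-8 assay, with a stated time of 72 h; on this read-out higher numbers stand for weaker inhibition and lower numbers for stronger inhibition:
compound 1 `COc1ccccc1/C=c1/[nH]c(=O)/c(=C\c2cccc(Cl)c2Cl)[nH]c1=O` gives "not active" (no number reported)
compound 2 `C=CCn1c(=O)/c(=C\c2ccccc2Cl)[nH]c(=O)/c1=C\c1ccccc1OC` gives 2500 nM
compound 3 `C=CCn1c(=O)/c(=C\c2cccc(Br)c2)[nH]c(=O)/c1=C\c1ccccc1OC` gives 2400 nM

Compound 1 stands without a number in this assay: it is reported only as inactive, so no figure marks its distance from compounds 2 and 3. Compound 4 `COc1ccccc1/C=c1\c(=O)[nH]/c(=C/c2cccc(Cl)c2Cl)c(=O)n1C` differs from compound 1 by methyl in place of hydrogen on an aromatic nitrogen. Among the measured compounds shown here, no measured pair isolates this change. For the measured compounds named here, the only measured step, a 1.0-fold lower number from compound 2 to compound 3 (0.02 log units; within the scatter), concerns the aryl group on a double-bonded chain carbon and stays within the scatter; it says nothing about the ring nitrogen. Compounds 2 and 3 carry an allyl group on that nitrogen and both give numbers where compound 1 gives none, but their aryl groups also differ from compound 1, so no direction can be read for the methyl. Compounds 2 and 3 are the nearest reference. For compound 4 in this assay the expected value is 3500 nM. The estimated range for compound 4 runs from 1200 nM to 15000 nM, with a real chance that only inactivity is reported again.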

Compound 4, half-maximal inhibitory concentration: 110 nM
The estimate for compound 4 lay 32-fold (1.50 log units) above the measured number, outside the stated range (below it).
By their numbers in this assay, from the lowest: compound 4; then compounds 3 and 2 (each within the scatter of the next).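

Among the compounds shown here, compound 1 has no number, only the report "not active" (no number reported), so no step to compound 4 can be read. The compounds shown leave open what methyl in place of hydrogen on the aromatic nitrogen does by itself. No measurement shown bears on a cause for the value of compound 4.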